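Azido to acetoxy in a microsomal stability series

The source may report more compounds than this note shows. Statements on the series, on what has been measured and on what is new or still open speak of the compounds shown alone.

In an ADME assay on microsomes from liver (Homo sapiens) for metabolic stability, read by LC-MS, with NADPH named in the record, with a stated time of 60 min, tested at 1 uM, in the absence of a further agent (on this read-out higher numbers stand for a more stable compound and lower numbers for a less stable compound), compound 1 (`COc1ccc(-c2c(C)nc3c(N4CC[C@@H](NC(=O)NC(C)C)C4)cc(C)nn23)cc1OC`) gives > 95% as a limit of the assay. Compound 2 (`COc1ccc(-c2c(C)nc3c(N4CC[C@@H](NS(=O)(=O)c5cccs5)C4)cc(C)nn23)cc1OC`) gives > 95% as a limit too. Compound 3 (`COc1ccc(-c2c(C)nc3c(N4CC[C@@H](N=[N+]=[N-])C4)cc(C)nn23)cc1OC`) gives > 95% and this is again only a limit, not a number. Compound 4 (`COc1ccc(-c2c(C)nc3c(N4CC[C@@H](OC(C)=O)C4)cc(C)nn23)cc1OC`) carries acetoxy in place of azido on a saturated ring carbon. Two measured swaps at that carbon bear on this change (a step that the two limits leave unreadable from compound 1 to compound 3 and a step that the two limits leave unreadable from compound 2 to compound 3). Neither offers a size to carry over because of the limit of > 95% in this assay, at which 3 of the 3 values shown sit, in all three compounds. Acetoxy itself has not been measured here, so only a modest fall is expected (the estimate reads a number at least 10 percentage points lower from compound 3 to compound 4 (that floor lies within the scatter) in size). Compound 4 is estimated at 85% (expected range 50% to 100%).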

Compound 4, percent of the compound remaining: > 95%
Compound 4: no number, only a limit; the forecaster's own chance of this, stated with the estimate: 45%; middle value at least 10 percentage points away from the limit.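

Within the data shown here, no step from compound 1, compound 2 or compound 3 to compound 4 can be read, because all four compounds share the same limit: the limit of > 95% in this assay, at which 4 of the 4 values shown sit. On these data alone, whether these four compounds differ in stability at all, and by how much, stays open.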